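A few compounds are considered here, and "the series" means these few. Any claim that something is new, unique, unknown or untested is made for them only; others in the source may bear on it.

Measured compounds:
Compound 1, `CC(C)CCn1nc(C(=O)N[C@H]2COc3ccccc3N(C)C2=S)nc1Cc1ccccc1`, in a toxicity assay on HT-29 cells (Homo sapiens) for cytotoxicity (a lower number here means that less compound is tolerated, a higher number that more compound is tolerated), reaches only the assay limit of > 100000 nM.
Compound 2, `CN1C(=S)[C@@H](NC(=O)c2nc(Cc3ccccc3)n(CCC(F)(F)F)n2)COc2ccccc21`, gives in this assay only the limit of > 100000 nM.
Compound 3, `CN1C(=S)[C@@H](NC(=O)c2nc(Cc3ccccc3)n(C3CCCC3)n2)COc2ccccc21`, gives in this assay only the limit of > 100000 nM.

Compound 1 therefore stands at the upper edge of what this assay can report: no number, only a limit. The same holds for every measured compound here, as the limit of > 100000 nM in this assay, at which 3 of the 3 values shown sit, records.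

Compound 4, `Cc1cnc(-n2nc(C(=O)N[C@H]3COc4ccccc4N(C)C3=S)nc2Cc2ccccc2)nc1`, is the compound still to be measured. It differs from compound 1 in one place: 5-methylpyrimidin-2-yl in place of isopentyl on an aromatic nitrogen.

For the measured compounds named here, three measured steps bear on changes at that same aromatic nitrogen. The step that the two limits leave unreadable from compound 1 to compound 2, the step that the two limits leave unreadable from compound 1 to compound 3 and the step that the two limits leave unreadable from compound 2 to compound 3 all leave no readable size, since each compound involved sits at the limit. None of them shows a measurable change at this position, so no direction or size of step in this assay can be read for compound 4 either.

Compound 4 is therefore expected to sit at the limit again, the estimated step being a number no higher from compound 1 to compound 4 (the limit leaves the size open).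

For compound 4 the estimate in this assay is 100000 nM, with a range from 50000 nM to 300000 nM.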

Compound 4, half-maximal cytotoxic concentration: > 100000 nM
Compound 4: a limit, no number; the forecaster's own chance of this, stated with the estimate: 85%; the middle value sits exactly at the limit.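

In this assay compound 4 gives > 100000 nM, which is a limit and not a number. No new step can be read from compound 1, compound 2 or compound 3 to compound 4, because all four compounds sit at the same limit: the limit of > 100000 nM in this assay, at which 4 of the 4 values shown sit.

The compounds shown leave open whether the groups on the aromatic nitrogen differ at all in this assay, and by how much.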